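Removing the acetyl from the anilide of compound 2

The source may hold more compounds than are shown below. What is called first, only, known or untested is meant among the compounds shown, and "the series" means these compounds.

Measured compounds in this series:
- compound 1 `C=CCc1cc(C(=O)CCC)ccc1OCCCNC(C)C`: 1 nM
- compound 2 `C=CCc1cc(NC(C)=O)ccc1OCCCNC(C)C`: 65 nM

In an assay for inhibition of squalene synthase (Rattus norvegicus), using microsomes (on this read-out higher numbers stand for weaker inhibition and lower numbers for stronger inhibition), compound 1 gives 1 nM. Compound 2 carries an acetamido on the aromatic carbon where compound 1 carries a propylcarbonyl, and in this assay compound 2 gives 65 nM. Among the measured compounds shown here, the single measured step, a 65-fold higher number from compound 1 to compound 2 (1.81 log units; beyond the scatter), is the only comparison available; compound 2 therefore stands as the higher of the two numbers.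

Compound 3 `C=CCc1cc(N)ccc1OCCCNC(C)C` has not been measured. It differs from compound 2 by hydrogen in place of acetyl on a nitrogen on an aromatic ring. For the measured compounds named here, no measured step removes an acetyl from an anilide nitrogen, so the direction cannot be read off directly. Going by the values given here, the one step that is known, a 65-fold higher number from compound 1 to compound 2 (1.81 log units; beyond the scatter), shows that changing the group on that aromatic carbon can move the number by a large amount, and the acetyl leaving compound 2 takes away the carbonyl that both measured substituents share. Expected is a further weakening, a 4.6-fold higher number from compound 2 to compound 3 (0.66 log units; beyond the scatter), of modest size. Compound 3 is estimated at 300 nM, within a range of 60 nM to 1500 nM.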

Compound 3, half-maximal inhibitory concentration: 250 nM
The estimate for compound 3 lay 1.2-fold (0.08 log units) above the measured number, within the range that was stated.
By their numbers in this assay, from the lowest: compound 1; then compound 2; then compound 3.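

In this assay, removing the acetyl from the anilide nitrogen gives a 3.8-fold higher number from compound 2 to compound 3 (0.59 log units; beyond the scatter) and is a modest step, so the acetamido group is not the floor at this position: the bare amino reads weaker still. Set against the propylcarbonyl, the same amino gives a 250-fold higher number from compound 1 to compound 3 (2.40 log units; beyond the scatter) as the largest step in the series, and the three groups on this aromatic carbon now fall in a clear order, with propylcarbonyl lowest, acetamido in the middle and amino highest, each step beyond the scatter. Most of that total span already appears on going from propylcarbonyl to acetamido, and the removal of the acetyl adds a smaller part; nothing measured here bears on why the number moves this way at this position.

The compounds shown do not separate the carbonyl from the chain attached to it, so it remains open how a shorter acetyl ketone, a longer butanoyl ketone or a carboxylic acid on this aromatic carbon would read. From the compounds shown here alone, the rest of the core is shared by all three compounds, and whether the same order holds with a different amine at the end of the ether chain also remains open.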